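This account rests on a few compounds, and the source may have more. Where it says the series, first, only, none or still open, it means among the compounds named here.

Working notes on the series. In an assay on CHO cells for inhibition of Vasopressin V2 receptor (Homo sapiens), read by radioligand binding (a higher number here means a weaker inhibitor, a lower number a stronger inhibitor), compound 1 `O=C(Nc1ccc(C(=O)N2CCCN(Cc3ccccc3)c3sccc32)cc1)c1ccccc1-c1ccccc1` gives 80 nM. In this assay compound 2 `O=C(Nc1ccc(C(=O)N2CCCN(CCN3CCCC3)c3sccc32)cc1)c1ccccc1-c1ccccc1` gives 200 nM. Compound 3 `O=C(Nc1ccc(C(=O)N2CCCCc3sccc32)cc1O)c1ccccc1-c1ccccc1` returns only a limit of the assay rather than a number, < 10 nM in this assay; this is the limit recorded as the limit of < 10 nM in this assay, at which 1 of the 3 values shown sits.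

Among the two numbers shown, compound 2 stands at the highest; its nearest neighbour is compound 1, from which it is separated by the step of a 2.5-fold higher number from compound 1 to compound 2 (0.40 log units; beyond the scatter).

Compound 4 `CN(C)CCN1CCCN(C(=O)c2ccc(NC(=O)c3ccccc3-c3ccccc3)cc2)c2ccsc21` differs from compound 2 by dimethylamino in place of pyrrolidin-1-yl on a saturated chain carbon, two bonds along the chain from a nitrogen on an aromatic ring in a ring. Within the data shown here, no measured step covers this exchange directly. Among the measured compounds shown here, the one step recorded, a 2.5-fold higher number from compound 1 to compound 2 (0.40 log units; beyond the scatter), replaces a phenyl with the whole (pyrrolidin-1-yl)methyl group and was only modest, whereas the change to compound 4 keeps the chain and swaps just the group on its saturated chain carbon, pyrrolidin-1-yl for dimethylamino. Compound 4 is therefore expected to sit close to compound 2, with a step of no change at the digits printed from compound 2 to compound 4 (within the scatter) that is not expected to reach beyond the scatter. In this assay compound 4 is estimated at 200 nM, in the range 80 nM to 500 nM.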

Compound 4, half-maximal inhibitory concentration: 80 nM
Compound 4: the middle estimate sits 2.5-fold (0.40 log units) above what was measured; measured number inside the range.
By their numbers in this assay, from the lowest: compounds 1 and 4 (each within the scatter of the next); then compound 2. At a limit, below all of these: compound 3.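

Among these compounds, with the chain kept, the group on its saturated chain carbon, two bonds along the chain from a nitrogen on an aromatic ring in a ring, is not neutral in this assay: dimethylamino in place of pyrrolidin-1-yl gives a 2.5-fold lower number from compound 2 to compound 4 (0.40 log units; beyond the scatter), a modest step that the earlier compounds could not isolate, since their only step exchanged phenyl for the whole (pyrrolidin-1-yl)methyl group. The same comparison now separates the two amines: the step away from phenyl depends on which amine ends the chain, and (dimethylamino)methyl in place of phenyl gives no change at the digits printed from compound 1 to compound 4 (within the scatter), so the phenyl of compound 1 and the (dimethylamino)methyl of compound 4 cannot be told apart in this read-out. Nothing measured among the compounds shown accounts for either step.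

Still open, on these data alone, is whether the number follows the ring of pyrrolidin-1-yl or only the count of heavy atoms in the group, since one pair of amines cannot separate the two. Diethylamino, morpholin-4-yl or a primary amine at the same place would test this, and a longer chain carrying dimethylamino would show whether the distance from the nitrogen on the aromatic ring matters as well.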